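The source may hold more compounds than are shown below. What is called first, only, known or untested is meant among the compounds shown, and "the series" means these compounds.

Compound 1 `O=c1ccoc2cc(OCc3cn(Cc4ccc(Cl)cc4)nn3)ccc12` in a functional assay on MDA-MB-231 cells (Homo sapiens) for cytotoxicity, read by MTT assay, with a stated time of 48 h (a lower number here means a stronger inhibitor, a higher number a weaker inhibitor), gives > 100000 nM, a limit of the assay rather than a number. Compound 2 `O=c1ccoc2cc(OCc3cn(Cc4cccc([N+](=O)[O-])c4)nn3)ccc12` gives > 100000 nM, again only a limit. Compound 3 `O=c1ccoc2cc(OCc3cn(Cc4ccccc4Cl)nn3)ccc12` gives 15100 nM.

Compound 3 thus holds the only number shown; the other two values sit at the limit (the limit of > 100000 nM in this assay, at which 2 of the 3 values shown sit). The step that the two limits leave unreadable from compound 1 to compound 2 cannot be read. The steps of an at least 6.6-fold lower number from compound 1 to compound 3 (0.82 log units; beyond the scatter) and an at least 6.6-fold lower number from compound 2 to compound 3 (0.82 log units; beyond the scatter) are at least modest. Compound 4 `COc1ccc(Cn2cc(COc3ccc4c(=O)ccoc4c3)nn2)cc1` differs from compound 3 by 4-methoxyphenyl in place of 2-chlorophenyl on a saturated chain carbon bound to an aromatic nitrogen. For the measured compounds named here, no measured step covers a methoxy group; the only guide is that compounds 1 and 2, with substituents away from the ortho-like position of compound 3, reached only the limit. Compound 4 is therefore expected to give a higher number, a 4.0-fold higher number from compound 3 to compound 4 (0.60 log units; beyond the scatter), estimated at 60000 nM within 15000 nM to 200000 nM.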

Compound 4, half-maximal inhibitory concentration: > 100000 nM
Compound 4 ended at the assay's limit; the forecaster's own chance of this, stated with the estimate: 40%; middle value at least 1.6-fold (0.22 log units) away from the limit.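

In this assay, replacing the 2-chlorophenyl group gives an at least 6.6-fold higher number from compound 3 to compound 4 (0.82 log units; beyond the scatter), so a methoxy group does no better here than the chloro of compound 1 or the nitro of compound 2. The steps among compounds 1, 2 and 4, all limits of the assay, cannot be read. Compound 3 remains the only one of the four with a number, and the others stop at a limit: the limit of > 100000 nM in this assay, at which 3 of the 4 values shown sit.

On these data alone, it stays open whether the number of compound 3 depends on chloro itself or on where it sits. An unsubstituted phenyl, a 2-methoxyphenyl or a 2-aminophenyl group at this place could separate the two.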